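The source may hold more compounds than are shown below. What is called first, only, known or untested is meant among the compounds shown, and "the series" means these compounds.

Compound 1 `C=CCn1c(N)c(C#N)c2c(N)ncnc21` reads > 100000 nM in a functional assay on KB cells (Homo sapiens) for inhibition (on this read-out lower numbers stand for stronger inhibition and higher numbers for weaker inhibition), which is a limit and not a number. It stands at the limit of > 100000 nM in this assay, at which 2 of the 3 values shown sit. Compound 3 `CCOCn1c(Br)c(C#N)c2c(N)ncnc21` reads > 100000 nM, also a limit. For the measured compounds named here, compound 2 `CCOCn1cc(C(=N)S)c2c(N)ncnc21` gives 60000 nM, the only true number in the set. Compound 4 `N#Cc1c(N)n(Cc2ccccc2)c2ncnc(N)c12` differs from compound 1 by phenyl in place of vinyl on a saturated chain carbon bound to an aromatic nitrogen. Going by the values given here, no measured pair differs in one place, so only a small expected move toward stronger inhibition in this assay is assumed, with an at least 1.4-fold lower number from compound 1 to compound 4 (0.15 log units; that floor lies within the scatter) as the estimated step. Among the compounds with values here, this rests on compound 2 at 60000 nM as the only reading inside the range of the assay. For compound 4 the estimated value is 70000 nM, with an expected range from 20000 nM to 150000 nM.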

Compound 4, half-maximal inhibitory concentration: 34000 nM
Estimate against measurement, compound 4: 2.1-fold (0.31 log units) above; the range from low to high includes it.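

Phenyl in place of vinyl on a saturated chain carbon bound to an aromatic nitrogen gives an at least 2.9-fold lower number from compound 1 to compound 4 (0.46 log units; beyond the scatter) in this assay, so this position responds to the substituent on the shared core. Compound 4 gives 34000 nM, a true number on this read-out. Compound 1 stands at a limit, so the step has a floor but no exact size: the limit of > 100000 nM in this assay, at which 2 of the 4 values shown sit.

Still open, from the compounds shown here alone, is whether a longer chain, such as phenethyl, moves the number further. Also open, going by these compounds, is whether a phenyl carrying an amine or a carboxylic acid does so.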